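The compounds below may be only part of what the source reports. "The series", "measured", "known", "first", "only" and "open" are said of these compounds alone.

In an assay on microsomes from liver for inhibition of sterol O-acyltransferase 1 (Rattus norvegicus) (on this read-out lower numbers stand for stronger inhibition and higher numbers for weaker inhibition), compound 1 `CCCCCCCCCCCCn1nnc(C(NC(=O)c2ccccc2C(F)(F)F)c2ccccc2)n1` gives 120 nM, and compound 2 `CCCCCCCCCCCCn1nnnc1C(NC(=O)c1ccc(F)cc1F)c1ccccc1` gives 380 nM. Compound 2 thus stands at the higher of the two numbers, its gap to compound 1 lying beyond the usual scatter. Compound 3 `CCCCCCCCCCCCn1nnnc1C(NC(=O)c1ccccc1C(F)(F)F)c1ccccc1` carries the change (2-(trifluoromethyl)phenyl in place of 2,4-difluorophenyl on a carbonyl carbon), which places on the core of compound 2 the same acyl group that compound 1 bears. Within the data shown here, no measured pair isolates this change on one core. The number for compound 3 is expected to fall, with the step of a 2.5-fold lower number from compound 2 to compound 3 (0.40 log units; beyond the scatter) beyond the scatter, because compound 1 with this group gives 120 nM. Compound 3 is estimated at 150 nM, within 60 nM to 400 nM.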

Compound 3, half-maximal inhibitory concentration: 350 nM
The estimate for compound 3 lay 2.3-fold (0.37 log units) below the measured number; low and high end bracket the measured number.
By their numbers in this assay, from the lowest: compound 1; then compounds 3 and 2 (each within the scatter of the next).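

On the core of compound 2, the carbonyl carbon accepts 2-(trifluoromethyl)phenyl in place of 2,4-difluorophenyl with a 1.1-fold lower number from compound 2 to compound 3 (0.04 log units; within the scatter), so this exchange does not separate the two compounds on this read-out. The acyl group shared with compound 1, at 120 nM, does not by itself bring compound 3 to that number. No available evidence accounts for this result.

Still open, going by these compounds, is whether an amine or a carboxylic acid in place of the aryl group on this carbonyl carbon would shift the number on the shared core.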